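This account rests on a few compounds, and the source may have more. Where it says the series, first, only, none or still open, it means among the compounds named here.

Measured so far:
compound 1, `c1ccc(C(/N=C2\CCCCCN2)C2CC2)cc1`: 51%
compound 2, `COc1ccc(C(/N=C2\CCCCCN2)C2CC2)cc1`: 40%

Compound 1 stands highest of the two numbers in a functional assay on the whole organism (plasma, strain Sprague-Dawley) with Rattus norvegicus as the target, with a stated time of 2 h, at a dose of 100 mg/kg by the oral route; on this read-out lower numbers stand for a weaker effect and higher numbers for a stronger effect at the one dose given; its nearest neighbour is compound 2, reached by a number 11 percentage points lower from compound 1 to compound 2 (beyond the scatter), a change of methoxy in place of hydrogen on an aromatic carbon. Compound 3, `c1ccc(C(/N=C2\CCCCCN2)c2ccco2)cc1`, differs from compound 1 by furan-2-yl in place of cyclopropyl on a saturated chain carbon bound to an aromatic carbon and a double-bonded nitrogen. For the measured compounds named here, no measured step touches this part of the shared core, and the single known step, which alters an aromatic carbon, does not bear on it. One therefore expects no step beyond the scatter, estimated as a number 6 percentage points lower from compound 1 to compound 3 (within the scatter). Compound 3 is expected to give 45% in this assay, within 20% to 70%.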

Compound 3, a percentage reported as inhibition, in the whole organism at one dose (the size of the read-out at that dose, not a potency): 52%
Estimate against measurement, compound 3: 7 percentage points below; the range from low to high includes it.
By their numbers in this assay, from the lowest: compound 2; then compounds 1 and 3 (each within the scatter of the next).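

In this assay, furan-2-yl in place of cyclopropyl on a saturated chain carbon bound to an aromatic carbon and a double-bonded nitrogen gives a number 1 percentage points higher from compound 1 to compound 3 (within the scatter). This position, which the earlier step did not touch, thus accepts a five-membered aromatic ring with 1 hetero atom in place of a three-membered non-aromatic ring of carbon only, with no step beyond the scatter. Nothing available accounts for this result.

From the compounds shown here alone, whether an amine or a longer chain at this position would leave the read-out equally unchanged stays open. So does whether methoxy on an aromatic carbon of compound 3 would lower the number as it does in a number 11 percentage points lower from compound 1 to compound 2 (beyond the scatter).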